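Benzyloxy to allyloxy at the cytotoxicity limit

A few compounds are considered here, and "the series" means these few. Any claim that something is new, unique, unknown or untested is made for them only; others in the source may bear on it.

Compound 1 `C=CCONC(=O)C(C)N1C(=O)S/C(=C\c2ccccc2)C1=O`: > 128000 nM
Compound 2 `C=CCONC(=O)CN1C(=O)S/C(=C\c2ccc(F)cc2)C1=O`: > 128000 nM
Compound 3 `CC(C(=O)NOCc1ccccc1)N1C(=O)S/C(=C\c2ccc(F)cc2)C1=O`: > 128000 nM

All three entries come from an ADME assay on RAW264.7 cells (Mus musculus) for cytotoxicity, read by neutral red uptake, with a stated time of 24 h (on this read-out lower numbers stand for higher toxicity in this test and higher numbers for lower toxicity in this test), and each is a limit, not a number. In this assay compound 3 gives > 128000 nM, which is a limit. Among the compounds with values here, the whole series so far stands at the limit of > 128000 nM in this assay, at which 3 of the 3 values shown sit.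

Compound 4 `C=CCONC(=O)C(C)N1C(=O)S/C(=C\c2ccc(F)cc2)C1=O` differs from compound 3 in one place: vinyl in place of phenyl on a saturated chain carbon bound to an oxygen, which turns benzyloxy into allyloxy. No measured step sizes this change. Compound 2 also carries allyloxy and gives > 128000 nM, again a limit. No change beyond the usual scatter is expected, and the estimated step is a number no higher from compound 3 to compound 4 (the limit leaves the size open). Compound 4 is expected at 128000 nM, with an estimated range of 64000 nM to 256000 nM.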

Compound 4, half-maximal cytotoxic concentration: > 128000 nM
Compound 4: a limit, no number; the forecaster's own chance of this, stated with the estimate: 85%; the middle value lies on the limit itself.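

In this assay compound 4 gives > 128000 nM, which is a limit. Within the data shown here, no step from compound 1, compound 2 or compound 3 to compound 4 can be read. The compounds shown leave open whether any of these changes alters cytotoxicity, because all four values stop at the same limit: the limit of > 128000 nM in this assay, at which 4 of the 4 values shown sit.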